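The compounds below may be only part of what the source reports. "The series", "measured", "known", "first", "only" and "open" are said of these compounds alone.

Three compounds have been run through a functional assay on K562 cells (Homo sapiens) for cytotoxicity, read by MTT assay, with a stated time of 5 days; a higher number here means a weaker inhibitor, a lower number a stronger inhibitor. In this assay compound 1, whose structure is `COc1ccc(-c2cn(-c3cc(OC)c(OC)c(OC)c3)nn2)cc1O`, gives > 10000 nM, which is a limit of the assay and not a number. In this assay compound 2, with the structure `COc1ccc(-c2cn(-c3cc(OC)c(OC)c(OC)c3)nn2)cc1[N+](=O)[O-]`, gives > 10000 nM, again a limit rather than a number. In this assay compound 3, drawn as `COc1ccc(Cn2cc(-c3cc(OC)c(OC)c(OC)c3)nn2)cc1O`, gives > 10000 nM, once more a limit and not a number.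

Compound 2 differs from compound 1 by nitro in place of hydroxy on an aromatic carbon. Because both values rest at the limit of > 10000 nM in this assay, at which 3 of the 3 values shown sit, the step in this assay is a step that the two limits leave unreadable from compound 1 to compound 2. Compound 3 carries a different core from compound 1, but the difference between the two cores is not broken down here.

The unmeasured compound 4, with the structure `COc1ccc(Cn2cc(-c3cc(OC)c(OC)c(OC)c3)nn2)cc1[N+](=O)[O-]`, differs from compound 3 by nitro in place of hydroxy on an aromatic carbon. Among the measured compounds shown here, this is the same change as the one from compound 1 to compound 2, set in a place described in the same words in both cases. Because compound 3 stands at > 10000 nM and the earlier step from compound 1 to compound 2 is a step that the two limits leave unreadable from compound 1 to compound 2, the step expected in this assay is a step that the limit leaves unreadable from compound 3 to compound 4. Compound 4 is therefore estimated to come out near 20000 nM in this assay, somewhere between 7000 nM and 60000 nM, most probably reported only as a limit once more.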

Compound 4, half-maximal inhibitory concentration: > 10000 nM
Compound 4: no number, only a limit; the forecaster's own chance of this, stated with the estimate: 85%; the middle value lies beyond the limit too.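

Compound 4 stays at a limit of the assay, as compound 3 does, so neither this pair nor any other pair shown yields a readable step in this assay: the limit of > 10000 nM in this assay, at which 4 of the 4 values shown sit.

The compounds shown leave open how strong any of them actually is in this assay, and whether nitro in place of hydroxy changes the read-out at all.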